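This account rests on a few compounds, and the source may have more. Where it says the series, first, only, none or still open, it means among the compounds named here.

Measured so far, in a functional assay on ACHN cells (Homo sapiens) for inhibition, read by sulforhodamine B assay, with a stated time of 48 h, tested at 0.01 uM; a higher number here means a weaker effect of the compound at the concentration tested, a lower number a stronger effect:

- compound 1 `O=C(Nc1cccc(-n2cc(-c3ccncc3)c(-c3cc(O)cc(Cl)c3)n2)c1)Nc1ccc(Cl)c(C(F)(F)F)c1` gives 104%
- compound 2 `COc1cc(Cl)cc(-c2nn(-c3cccc(NC(=O)Nc4ccc(Cl)c(C(F)(F)F)c4)c3)cc2-c2ccncc2)c1` gives 91%
- compound 3 `COc1cc(Cl)cc(-c2nn(-c3cccc(NC(=O)Nc4cc(C(F)(F)F)cc(C(F)(F)F)c4)c3)cc2-c2ccncc2)c1` gives 103%

Compound 2 stands lowest of these three numbers, beyond the scatter from each of the others, though all three sit close to the level of untreated cells. Going by the values given here, the only step that can be followed directly is the one from compound 1 to compound 2, where a methyl replaces hydrogen on an oxygen on an aromatic ring; it gave a number 13 percentage points lower from compound 1 to compound 2 (beyond the scatter). Compound 3 differs from compound 2 in the aryl group of the urea, and its number is the higher of the two.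

Compound 4 `COc1cc(Cl)cc(-c2nn(-c3cccc(NC(=O)c4cccc(C(F)(F)F)c4)c3)cc2-c2ccncc2)c1` is not yet measured. It differs from compound 2 by 3-(trifluoromethyl)phenyl in place of (4-chloro-3-(trifluoromethyl)phenyl)amino on a carbonyl carbon, so the urea of compound 2 becomes an amide. Among the compounds with values here, none of the measured steps touches this part of the molecule, and the step from compound 1 to compound 2 concerns a different position altogether. With no comparable change on record, and all three measured numbers lying near full activity, a change beyond the scatter in this assay is not expected. Compound 4 is therefore estimated at 97%, within 85% to 110%, which would mean an expected step of a number 6 percentage points higher from compound 2 to compound 4 (within the scatter).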

Compound 4, a percentage reported as activity, at one concentration (the size of the read-out at that concentration, not a potency): 98%
Estimate against measurement, compound 4: 1 percentage points below, and the stated range covers the measured number.
By their numbers in this assay, from the lowest: compounds 2, 4, 3 and 1 (each within the scatter of the next, the first and the last beyond it).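

Going by these compounds alone, this is the first change on record at the carbonyl carbon, where the urea of compound 2 becomes the amide of compound 4. In this assay the swap of (4-chloro-3-(trifluoromethyl)phenyl)amino for 3-(trifluoromethyl)phenyl gives a number 7 percentage points higher from compound 2 to compound 4 (within the scatter) at the single concentration tested, so this read-out separates neither the urea from the amide nor the two aryl groups, even though the group that leaves carries a nitrogen, a chlorine and a hydrogen-bond donor that the entering group lacks. Since those features go together in one step, none can be judged alone, and no measurement available here bears on the reason for this result.

A single pair at one concentration also leaves open whether the two compounds would still match at a concentration where cell growth falls clearly, as a read-out close to the untreated level says little about the size of the effect at other concentrations. As far as these compounds go, it also remains open how the amide would respond to a 4-chloro-3-(trifluoromethyl)phenyl group on its carbonyl carbon, which would separate the chlorine from the urea nitrogen, or to a morpholine or a longer alkyl chain there.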